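Ethyl in Place of Bromo: Compound 4 Expected

The source may hold more compounds than are shown below. What is called first, only, known or untested is meant among the compounds shown, and "the series" means these compounds.

Three compounds share one core. Compound 1 `Cc1cccc(Cn2c(CN3CCN(C(=O)c4ccc([N+](=O)[O-])cc4)CC3)nc3ccccc32)c1` gives 24.3% in an assay on isolated protein for inhibition of aldehyde dehydrogenase 1A1 (Homo sapiens), read by spectrophotometry, tested at 10 uM (on this read-out lower numbers stand for less inhibition and higher numbers for more inhibition at the one concentration tested (going by the name of the read-out)), compound 2 `Cc1cccc(Cn2c(CN3CCN(C(=O)c4ccc(Cl)cc4)CC3)nc3ccccc32)c1` gives 23.2%, and compound 3 `Cc1cccc(Cn2c(CN3CCN(C(=O)c4ccc(Br)cc4)CC3)nc3ccccc32)c1` gives 25.8%. The steps among them are all small: a number 1.1 percentage points lower from compound 1 to compound 2 (within the scatter), a number 1.5 percentage points higher from compound 1 to compound 3 (within the scatter) and a number 2.6 percentage points higher from compound 2 to compound 3 (within the scatter). Compound 3 thus holds the highest of the three numbers, but its nearest neighbour, compound 1, and its furthest, compound 2, both sit within the scatter of it, so no order can be read into the three.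

Compound 4 `CCc1ccc(C(=O)N2CCN(Cc3nc4ccccc4n3Cc3cccc(C)c3)CC2)cc1` differs from compound 3 in one place: ethyl in place of bromo on an aromatic carbon. For the measured compounds named here, the steps that bear on this change are those that swapped the same group on the same aromatic carbon, a number 1.5 percentage points higher from compound 1 to compound 3 (within the scatter) and a number 2.6 percentage points higher from compound 2 to compound 3 (within the scatter), neither of which moved the read-out beyond the scatter. The author therefore expects no step beyond the scatter in this assay for compound 4, and estimates a number 1.8 percentage points lower from compound 3 to compound 4 (within the scatter). Compound 4 is thus expected to give about 24%, with a range from 12% to 36%.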

Compound 4, a percentage reported as inhibition, at one concentration (the size of the read-out at that concentration, not a potency): 67%
Compound 4: middle estimate off by 43 percentage points, on the low side, and the stated range ends below it.
By their numbers in this assay, from the lowest: compounds 2, 1 and 3 (each within the scatter of the next); then compound 4.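

At this position, on an aromatic carbon para to a large group, the read-out in this assay does respond to the group placed there, as ethyl in place of bromo (a number 41.2 percentage points higher from compound 3 to compound 4 (beyond the scatter)), ethyl in place of chloro (a number 43.8 percentage points higher from compound 2 to compound 4 (beyond the scatter)) and ethyl in place of nitro (a number 42.7 percentage points higher from compound 1 to compound 4 (beyond the scatter)) all show. The absence of any step beyond the scatter therefore holds only among bromo, chloro and nitro, and compound 4 stands apart from all three. No measurement given here accounts for this separation.

The compounds shown leave open whether the step belongs to ethyl alone or also extends to other carbon groups such as methyl, a propyl chain or tert-butyl. They also leave open how a methoxy group or an amine would read at this same place.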